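The source may report more compounds than this note shows. Statements on the series, on what has been measured and on what is new or still open speak of the compounds shown alone.

Measured compounds:
compound 1, `Cc1cccc(S(=O)(=O)NCc2ccc(CNC(=O)c3ccccc3C)cc2)c1`, 1000 nM
compound 2, `Cc1ccccc1C(=O)NCc1ccc(CNS(=O)(=O)c2ccccc2F)cc1`, 1000 nM
compound 3, `COc1ccccc1C(=O)NCc1ccc(CNS(=O)(=O)c2ccccc2F)cc1`, 1 nM

The read-out throughout is an assay on MDA-MB-231 cells for displacement of a labelled ligand from C-X-C chemokine receptor type 4 (Homo sapiens), read by fluorescence and microscopy, with stated times of 10 min and 30 min; on this read-out higher numbers stand for an effect only at larger amounts of compound and lower numbers for an effect already at smaller amounts. Compound 2 stands level with compound 1, and together these two give the highest numbers of the three; the nearest value is that of compound 1, as no change at the digits printed from compound 1 to compound 2 (within the scatter) shows. The furthest is compound 3, reached by a 1000-fold lower number from compound 2 to compound 3 (3.00 log units; beyond the scatter), a change on an aromatic carbon of the amide-bearing ring.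

The unmeasured compound 4, `Cc1ccccc1C(=O)NCc1ccc(CNS(=O)(=O)c2cccc3ccccc23)cc1`, differs from compound 2 only on the sulfonyl sulfur: naphthalen-1-yl in place of 2-fluorophenyl on a sulfonyl sulfur.

Among the compounds with values here, only one measured step touches the same place. Exchanging one aryl group for another on the sulfonyl sulfur gave no change at the digits printed from compound 1 to compound 2 (within the scatter), a step within the scatter. The large step of a 1000-fold lower number from compound 2 to compound 3 (3.00 log units; beyond the scatter) lies elsewhere in the molecule and does not bear on the sulfonyl side. Within the data shown here, no measured pair shows what a two-ring aryl on that sulfur does. On this basis compound 4 is expected to stay close to compound 2, with no change at the digits printed from compound 2 to compound 4 (within the scatter) as the expected step. The estimate for compound 4 in this assay is 1000 nM, expected to fall between 250 nM and 4000 nM.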

Compound 4, effective concentration (reported as EC, without a stated level of effect): 100 nM
Beside the measured number, compound 4's estimate is 10-fold (1.00 log units) above it; measured number below the stated range.
By their numbers in this assay, from the lowest: compound 3; then compound 4; then compounds 1 and 2 (each within the scatter of the next).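

In this assay, the group on the sulfonyl sulfur now proves able to shift the number: naphthalen-1-yl gives a 10-fold lower number from compound 2 to compound 4 (1.00 log units; beyond the scatter) when it replaces 2-fluorophenyl and a 10-fold lower number from compound 1 to compound 4 (1.00 log units; beyond the scatter) when it replaces 3-methylphenyl. The exchange between those two single-ring groups had shown no change beyond the scatter, so the earlier compounds gave no sign that this side of the molecule could respond at all; the two-ring group shows that it can, although this step is smaller than the one on the amide-bearing ring, a 1000-fold lower number from compound 2 to compound 3 (3.00 log units; beyond the scatter) on the exchange of methyl for methoxy. Nothing offered here explains why naphthalen-1-yl lowers the number.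

The compounds shown cannot separate the effect of the second aromatic ring from that of the larger number of heavy atoms, since a single group brings both, and a saturated cyclohexyl group or a benzyl group on the sulfonyl sulfur would speak to that. Within the data shown here, it also remains open whether naphthalen-1-yl and the methoxy group of compound 3 would add up in one molecule, as no compound here carries both.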